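Swapping Diethylamino for a Thiomorpholine Ring on the Sulfonamide

The source may hold more compounds than are shown below. What is called first, only, known or untested is meant among the compounds shown, and "the series" means these compounds.

Of the compounds shown here, three sharing one core have been tested in an assay on a protein complex (Cavia porcellus) with sulfonylurea receptors; K-ATP channels (Homo sapiens) as the target; on this read-out lower numbers stand for stronger inhibition and higher numbers for weaker inhibition. Compound 1 `CN(C)S(=O)(=O)c1ccc(NC(=O)C(C)(O)C(F)(F)F)cc1` gives 480 nM, compound 2 `CCCN(CCC)S(=O)(=O)c1ccc(NC(=O)C(C)(O)C(F)(F)F)cc1` gives 6440 nM, and compound 3 `CCN(CC)S(=O)(=O)c1ccc(NC(=O)C(C)(O)C(F)(F)F)cc1` gives 810 nM. Compound 3 therefore stands second highest of the three: a 1.7-fold higher number from compound 1 to compound 3 (0.23 log units; within the scatter) lies within the scatter, whereas an 8.0-fold lower number from compound 2 to compound 3 (0.90 log units; beyond the scatter) lies beyond it. The change to compound 4 `CC(O)(C(=O)Nc1ccc(S(=O)(=O)N2CCSCC2)cc1)C(F)(F)F` is thiomorpholin-4-yl in place of diethylamino on a sulfonyl sulfur. The bearing steps all vary the group on the sulfonyl sulfur: a 13-fold higher number from compound 1 to compound 2 (1.13 log units; beyond the scatter) and an 8.0-fold lower number from compound 2 to compound 3 (0.90 log units; beyond the scatter) show that dipropylamino weakens inhibition, while dimethylamino and diethylamino sit within the scatter of each other. Since the entering ring carries the same four carbons as diethylamino, only a small step of a 1.5-fold higher number from compound 3 to compound 4 (0.17 log units; within the scatter) is expected. Compound 4 is estimated at 1200 nM, between 400 nM and 3600 nM.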

Compound 4, half-maximal inhibitory concentration: 4580 nM
For compound 4 the middle estimate is 3.8-fold (0.58 log units) below the measured one; measured number outside the range, above it.
By their numbers in this assay, from the lowest: compounds 1 and 3 (each within the scatter of the next); then compounds 4 and 2 (each within the scatter of the next).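

In this assay, the diethylamino group and the thiomorpholin-4-yl ring carry the same number of carbons, yet tying them into a sulfur-containing ring clearly weakens inhibition (a 5.7-fold higher number from compound 3 to compound 4 (0.75 log units; beyond the scatter)), and the gap to the dimethylamino compound is similar (a 9.5-fold higher number from compound 1 to compound 4 (0.98 log units; beyond the scatter)). The ring instead sits within the scatter of the dipropylamino compound (a 1.4-fold lower number from compound 2 to compound 4 (0.15 log units; within the scatter)), so the carbon count alone does not set the read-out at this position. No measurement shown here explains this step.

From the compounds shown here alone, whether the ring itself or its sulfur matters remains open. A piperidine or morpholine ring on the same sulfonyl sulfur would separate the two.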